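The compounds below may be only part of what the source reports. "The series", "measured", "known", "first", "only" and "open" are said of these compounds alone.

Among the measured compounds shown here, in a functional assay on HCT-116 cells (Homo sapiens) for inhibition, read by CCK-8 assay, with a stated time of 48 h (on this read-out higher numbers stand for weaker inhibition and lower numbers for stronger inhibition), compound 2 (`COc1cc(-c2ccnc3cc(-c4ccc(C(C)=O)cc4)nn23)cc(OC)c1OC`) reads 4390 nM and stands highest of the two numbers so far, above compound 1 (`C=Cc1ccc(-c2cc3nccc(-c4cc(OC)c(OC)c(OC)c4)n3n2)cc1`) at 1060 nM in the same read-out. Compound 3 (`CCOC(=O)c1ccc(-c2cc3nccc(-c4cc(OC)c(OC)c(OC)c4)n3n2)cc1`) has ethoxy in place of methyl on a carbonyl carbon relative to compound 2, which also reads as acetyl to ethoxycarbonyl. For the measured compounds named here, one measured step bears on this, and only loosely: a 4.1-fold higher number from compound 1 to compound 2 (0.62 log units; beyond the scatter) for acetyl in place of vinyl on an aromatic carbon, modest and beyond the scatter. Going by the values given here, no measured step changes the group on the carbonyl carbon alone. No step beyond the scatter is therefore expected in this assay for this change, and the expected step is a 1.1-fold lower number from compound 2 to compound 3 (0.04 log units; within the scatter) with a wide margin. For compound 3 the estimated value is 4000 nM with an expected range from 1500 nM to 11000 nM in this read-out.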

Compound 3, half-maximal inhibitory concentration: > 10000 nM
Compound 3: a limit, no number (the forecaster's own chance of this, stated with the estimate: 5%); at least 2.5-fold (0.39 log units) between middle value and limit.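

Compound 3 in this assay stands at a limit, not a number: the limit of > 10000 nM in this assay, at which 1 of the 3 values shown sits.
The change from acetyl to ethoxycarbonyl, with ethoxy in place of methyl on a carbonyl carbon, gives an at least 2.2-fold higher number from compound 2 to compound 3 (0.35 log units; beyond the scatter) as its read-out, so the group on this carbonyl carbon counts on its own, which the earlier step from vinyl to acetyl could not show. Against vinyl, the same position gives an at least 9.4-fold higher number from compound 1 to compound 3 (0.97 log units; beyond the scatter) as its read-out, and both carbonyl-bearing groups here read weaker than vinyl.

Going by these compounds, the true size of both steps stays open while compound 3 has only a limit. Also open, on these data alone, is whether a carboxylic acid or a primary amide in place of ethoxycarbonyl would bring the number back towards that of compound 1.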